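Truncating the carbonyl substituent of compound 2

The source may hold more compounds than are shown below. What is called first, only, known or untested is meant among the compounds shown, and "the series" means these compounds.

In a functional assay (aorta) with Rattus norvegicus as the target (a higher number here means a more potent compound, by a factor of ten per unit of this negative logarithm, a lower number a less potent compound), compound 1 `CC1(C)C=C(n2ccccc2=O)c2cc(C(=O)c3ccc(O)cc3)ccc2O1` gives 6.65 and compound 2 `CC1(C)C=C(n2ccccc2=O)c2cc(C(=O)c3ccccc3[N+](=O)[O-])ccc2O1` gives 6.17. Compound 2 stands lowest of the two numbers measured, with compound 1 nearest, the step between them being a number 0.48 log units lower from compound 1 to compound 2 (beyond the scatter). Compound 3 `CC1(C)C=C(n2ccccc2=O)c2cc(C=O)ccc2O1` differs from compound 2 by hydrogen in place of 2-nitrophenyl on a carbonyl carbon. Going by the values given here, no measured step covers this change: the one step known exchanges one six-membered aromatic ring for another, whereas here the whole ring is lost. A modest loss is expected, an estimated step of a number 0.57 log units lower from compound 2 to compound 3 (beyond the scatter). Compound 3 is therefore estimated at 5.6, within 4.9 to 6.3.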

Compound 3, logarithm of the reciprocal of the active concentration, log(1/C): 6.91
The estimate for compound 3 lay 1.31 log units below the measured number; the whole stated range lies below it.
By their numbers in this assay, from the lowest: compound 2; then compounds 1 and 3 (each within the scatter of the next).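

In this assay, the aromatic ring on this carbonyl carbon is not needed to keep the number up: hydrogen in place of 2-nitrophenyl gives a number 0.74 log units higher from compound 2 to compound 3 (beyond the scatter), and hydrogen in place of 4-hydroxyphenyl gives a number 0.26 log units higher from compound 1 to compound 3 (within the scatter). Of the two rings shown, only 2-nitrophenyl stands beyond the scatter from hydrogen. Nothing at hand bears on the reason for this result.

Going by these compounds, what a methyl group, an amine or a hydroxyl group on this carbonyl carbon would give remains open.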